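Methoxyphenyl in place of nitrophenyl on the chain

A few compounds are considered here, and "the series" means these few. Any claim that something is new, unique, unknown or untested is made for them only; others in the source may bear on it.

Compound 1 `O=C(/C=C\c1ccccc1[N+](=O)[O-])N1N=C(c2ccncc2)OC1c1c[nH]c2ccccc12`: > 30 ug/mL
Compound 2 `O=C(/C=C\c1cccc([N+](=O)[O-])c1)N1N=C(c2ccncc2)OC1c1c[nH]c2ccccc12`: > 30 ug/mL

In an ADME assay on HeLa cells (Homo sapiens) for cytotoxicity, read by MTT assay, with a stated time of 72 h (a lower number here means a stronger inhibitor of growth, a higher number a weaker inhibitor of growth), compound 1 gives > 30 ug/mL, which is a limit of the assay and not a number. Compound 2 gives > 30 ug/mL in this assay, likewise a limit. Within the data shown here, compound 2 thus stands at the limit, as does the one other value shown (the limit of > 30 ug/mL in this assay, at which 2 of the 2 values shown sit). The step that the two limits leave unreadable from compound 1 to compound 2 cannot be read; both of its ends are limits. Compound 3 `COc1ccc(/C=C\C(=O)N2N=C(c3ccncc3)OC2c2c[nH]c3ccccc23)cc1` differs from compound 2 by 4-methoxyphenyl in place of 3-nitrophenyl on a double-bonded chain carbon bound to a double-bonded chain carbon. Among the measured compounds shown here, the only measured step sits on the same chain carbon but yields neither size nor direction. With both measured values at the limit, compound 3 is expected to stay near it, the estimated step being a step that the limit leaves unreadable from compound 2 to compound 3, beyond the scatter in neither direction. Compound 3 is therefore estimated at 40 ug/mL, within 15 ug/mL to 120 ug/mL, and most likely only a limit will again be reported.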

Compound 3, concentration for 50% growth inhibition: > 30 ug/mL
Compound 3: a limit, no number (the forecaster's own chance of this, stated with the estimate: 75%); the middle value lies beyond the limit too.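

In this assay compound 3 gives > 30 ug/mL, a limit and not a number. No step among compound 1, compound 2 and compound 3 can be read: the limit of > 30 ug/mL in this assay, at which 3 of the 3 values shown sit.

The compounds shown leave open whether 2-nitrophenyl, 3-nitrophenyl and 4-methoxyphenyl on the chain differ at all in this assay.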